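The compounds below may be only part of what the source reports. "The series", "measured", "known", "first", "only" and "open" are said of these compounds alone.

Values in a functional assay on Raji cells (Homo sapiens) for antiproliferative activity, read by MTT assay, with a stated time of 48 h; a higher number here means a weaker inhibitor, a lower number a stronger inhibitor:
- Compound 1 `N#Cc1nc2c(-c3nc4ccccc4[nH]3)c(N)n(CCN3CCCC3)c2nc1C#N`: > 50000 nM (a limit)
- Compound 2 `CN1CCN(CCn2c(N)c(-c3nc4ccccc4[nH]3)c3nc(C#N)c(C#N)nc32)CC1`: > 50000 nM (a limit)
- Compound 3 `N#Cc1nc2c(-c3nc4ccccc4[nH]3)c(N)n(CCO)c2nc1C#N`: 5520 nM

Compound 2 has no number of its own, only a limit of > 50000 nM. Compound 1 is also a limit, at > 50000 nM. Together they make up (the limit of > 50000 nM in this assay, at which 2 of the 3 values shown sit). Only compound 3 gives a number, 5520 nM.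

The step under study leads to compound 4 `CCN(CC)CCCn1c(N)c(-c2nc3ccccc3[nH]2)c2nc(C#N)c(C#N)nc21`, which has yet to be measured. The structural change is (diethylamino)methyl in place of 4-methylpiperazin-1-yl on a saturated chain carbon, two bonds along the chain from an aromatic nitrogen. Read one bond further out, 2-(4-methylpiperazin-1-yl)ethyl gives way to 3-(diethylamino)propyl.

Three measured steps act at this same place. The first, a step that the two limits leave unreadable from compound 1 to compound 2, cannot be sized. The two readable ones, an at least 9.0-fold lower number from compound 1 to compound 3 (0.95 log units; beyond the scatter) and an at least 9.0-fold lower number from compound 2 to compound 3 (0.95 log units; beyond the scatter), both bring in hydroxy. Compound 4 gains no hydroxy, so those steps say little about it, and the nearer guide is the limit of compound 2 at > 50000 nM. No step beyond the scatter is therefore expected in this assay, and no direction can be assigned, with a further reading at the limit quite likely. The estimated step is a number no higher from compound 2 to compound 4 (the limit leaves the size open). For compound 4 the expected value is 50000 nM, within an estimated range of 15000 nM to 100000 nM.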

Compound 4, half-maximal inhibitory concentration: 1870 nM
For compound 4 the middle estimate is 27-fold (1.43 log units) above the measured one, outside the stated range (below it).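

In this assay, an amine on this side chain does not by itself hold a compound at the limit, as 3-(diethylamino)propyl gives an at least 26-fold lower number from compound 2 to compound 4 (1.42 log units; beyond the scatter) and an at least 26-fold lower number from compound 1 to compound 4 (1.42 log units; beyond the scatter). Hydroxy is also no longer the only group at this place to give a reading short of the limit, and the diethylamino chain goes further, with a 3.0-fold lower number from compound 3 to compound 4 (0.47 log units; beyond the scatter). Compound 1 and compound 2, which carry their amine in a ring on the shorter chain, remain the only compounds in this assay without a number of their own: the limit of > 50000 nM in this assay, at which 2 of the 4 values shown sit.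

The change to compound 4 opens the ring and lengthens the chain in one step, and the compounds shown cannot tell which of the two goes with the lower number; 2-(diethylamino)ethyl and 3-(4-methylpiperazin-1-yl)propyl, each carrying only one of the two changes, would separate them. Going by these compounds, the step between the two limits cannot be read, which leaves any difference between pyrrolidin-1-yl and 4-methylpiperazin-1-yl unknown, and whether a still longer chain would carry the trend further also stays open.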